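Para substituent swap on the shared core: methoxy to nitro

A few compounds are considered here, and "the series" means these few. Any claim that something is new, unique, unknown or untested is made for them only; others in the source may bear on it.

Measured compounds in an ADME assay on NIH3T3 cells (Mus musculus) for cytotoxicity, read by MTT assay; on this read-out higher numbers stand for weaker inhibition and lower numbers for stronger inhibition:
compound 1 `N#Cc1c(-c2ccccc2O)c(C#N)c(=O)n(/N=C/c2cn(-c3ccccc3)nc2-c2ccccc2)c1N` gives 162 ug/mL
compound 2 `COc1ccc(-c2c(C#N)c(N)n(/N=C/c3cn(-c4ccccc4)nc3-c3ccccc3)c(=O)c2C#N)cc1` gives 50 ug/mL

Compound 2 stands at the lower of the two numbers, with compound 1 the nearest at a higher value. Among the compounds with values here, the one measured step on this core, a 3.2-fold lower number from compound 1 to compound 2 (0.51 log units; beyond the scatter), changed the aryl group hanging from the core. Compound 3 `N#Cc1c(-c2ccc([N+](=O)[O-])cc2)c(C#N)c(=O)n(/N=C/c2cn(-c3ccccc3)nc2-c2ccccc2)c1N` keeps that arrangement and differs from compound 2 only at one point: nitro in place of methoxy on an aromatic carbon. Within the data shown here, no measured pair exchanges one para substituent for another, so the step from compound 1 to compound 2 bears on it only loosely, as a sign that a change on this ring can move the number modestly. A step of that order or smaller is therefore expected, without a clear direction. The estimate for compound 3 in this assay is 45 ug/mL, between 15 ug/mL and 140 ug/mL, which would mean a 1.1-fold lower number from compound 2 to compound 3 (0.05 log units; within the scatter).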

Compound 3, half-maximal inhibitory concentration: 84 ug/mL
The estimate for compound 3 lay 1.9-fold (0.27 log units) below the measured number; the range from low to high includes it.
By their numbers in this assay, from the lowest: compounds 2, 3 and 1 (each within the scatter of the next, the first and the last beyond it).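

In this assay, within the data shown here, the first exchange of one substituent for another at this place on the ring, nitro for methoxy para to a large group, gives a 1.7-fold higher number from compound 2 to compound 3 (0.23 log units; within the scatter). Set against the 2-hydroxyphenyl group, the 4-nitrophenyl group gives a 1.9-fold lower number from compound 1 to compound 3 (0.29 log units; within the scatter), so compound 3 cannot be told apart from either compound 1 or compound 2, even though those two stand apart with a 3.2-fold lower number from compound 1 to compound 2 (0.51 log units; beyond the scatter). Nothing available bears on what lies behind these numbers.

The step from compound 1 to compound 2 changes both the substituent and its place on the ring, so a 4-hydroxyphenyl group would be needed to separate the two changes. As far as these compounds go, it also remains open whether an amine or a carboxylic acid at this para place would stand clear of compound 2.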